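A few compounds are considered here, and "the series" means these few. Any claim that something is new, unique, unknown or untested is made for them only; others in the source may bear on it.

Compound 2, `N=C(N)c1ccc(-c2ccc(-c3ccc(Cl)cc3)s2)s1`, gives 49% in an ADME assay on cells (Erythrocyte, Homo sapiens) for activation, read by hemolysis, with a stated time of 30 min, tested at 5 mM; a higher number here means a stronger effect of the compound at the concentration tested, a lower number a weaker effect. Among the measured compounds shown here, of the two numbers so far it is the lowest; its nearest neighbour is compound 1, `N=C(N)c1ccc(-c2ccc(-c3ccc(F)cc3)o2)o1`, which in this assay gives 66.3%, a number higher by a gap that lies beyond the scatter. For the measured compounds named here, no pair of measured compounds differs in a single place, so no measured step is available to lean on.

Compound 3, `N=C(N)c1ccc(-c2ccc(-c3ccccc3)s2)s1`, is the one to be measured next in this assay. It differs from compound 2 in one place: hydrogen in place of chloro on an aromatic carbon. Going by the values given here, with no step of this kind to go by, nothing in the data points to a shift of a particular size or direction for this assay; the expectation is a step that stays within the scatter, or at most a small one, with the direction left open. Compound 3 is therefore expected to give 45% in this assay, in the range from 25% to 65%, which means an expected step of a number 4 percentage points lower from compound 2 to compound 3 (within the scatter).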

Compound 3, a percentage reported as activity, at one concentration (the size of the read-out at that concentration, not a potency): 56.7%
Compound 3: the middle estimate sits 11.7 percentage points below what was measured, and the stated range covers the measured number.
By their numbers in this assay, from the lowest: compounds 2, 3 and 1 (each within the scatter of the next, the first and the last beyond it).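

Among the compounds shown here, exchanging chloro for hydrogen on an aromatic carbon, para to a large group, gives in this assay a number 7.7 percentage points higher from compound 2 to compound 3 (within the scatter) and is the first change that can be read on its own, since compound 1 differs from compound 2 in more than one place. The step shows that, on this core and at this position, the read-out at the tested concentration does not depend measurably on chloro: with hydrogen in its place, the hemolysis stays within the usual scatter of the level seen with chloro. Nothing measured here bears on why the exchange leaves the read-out where it is.

From the compounds shown here alone, one exchange cannot show whether this position tolerates every group, so it remains open whether methoxy, an amine or a carboxylic acid in the same place would also leave the read-out within the scatter or would move it beyond. Going by these compounds, it also remains open whether the same exchange of chloro for hydrogen would give a step of similar size on the core of compound 1, which differs from compound 3 in more than one place and so cannot settle the question.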